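This account rests on a few compounds, and the source may have more. Where it says the series, first, only, none or still open, it means among the compounds named here.

Compound 1 `CCCC/N=C(\NC#N)Nc1cccnc1` — 20 mg/kg
Compound 2 `CCOCC/N=C(\NC#N)Nc1cccnc1` — > 20 mg/kg
Compound 3 `CCN(CC)CC/N=C(\NC#N)Nc1cccnc1` — not yet measured

Compound 2 stands at a limit of a functional assay on the whole organism (blood, strain Wistar-Okamoto) with Rattus norvegicus as the target, with a stated time of 5 days; a higher number here means that more compound is needed for the effect, a lower number that less compound is needed: in this assay compound 2 gives > 20 mg/kg, which is a limit and not a number. In this assay compound 1 gives 20 mg/kg. The step of a number no lower from compound 1 to compound 2 (the limit leaves the size open) therefore has no readable size, and the limit of > 20 mg/kg in this assay, at which 1 of the 2 values shown sits, is all that holds for it. Compound 3 differs from compound 2 by diethylamino in place of ethoxy on a saturated chain carbon, two bonds along the chain from a double-bonded nitrogen. No measured step touches diethylamino, and the one step that is shown is open in size, so the data give no direction for compound 3 one way or the other. It is therefore expected that compound 3 lands near where compound 2 sits, with the expected step of a number no higher from compound 2 to compound 3 (the limit leaves the size open) set at no change beyond the scatter. Compound 3 is estimated at 20 mg/kg, between 7 mg/kg and 60 mg/kg, with a fair chance that only a limit is reported again.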

Compound 3, minimum effective dose: > 8 mg/kg
Compound 3: no number, only a limit (the forecaster's own chance of this, stated with the estimate: 50%); the middle value lies beyond the limit too.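

In this assay compound 3 gives > 8 mg/kg, a limit and not a number, so no new step can be read from compound 3 to compound 1 or compound 2. The compounds shown leave open how ethyl, ethoxy and diethylamino compare in minimum effective dose.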